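A few compounds are considered here, and "the series" means these few. Any claim that something is new, unique, unknown or untested is made for them only; others in the source may bear on it.

Measured so far in an ADME assay on the whole organism (Rattus norvegicus, strain Lewis) for metabolic stability, at a dose of 2 mg/kg by the oral route; a lower number here means that the compound disappears faster, a higher number that the compound lasts longer:
- compound 1 `COc1ccc(OC[C@@H]2CCc3cc([C@H]4CC[C@](N)(CO)C4)ccc3C2)cc1`: < 10 h (a limit, not a number)
- compound 2 `Cc1ccc(OC[C@@H]2CCc3cc([C@H]4CC[C@](N)(CO)C4)ccc3C2)cc1`: 35 h (a number)

Within the data shown here, compound 2 holds the only number so far, since the other result stands at a limit (the limit of < 10 h in this assay, at which 1 of the 2 values shown sits). Compound 3 `COc1cccc(OC[C@@H]2CCc3cc([C@H]4CC[C@](N)(CO)C4)ccc3C2)c1` differs from it by 3-methoxyphenyl in place of 4-methylphenyl on an oxygen on a saturated carbon with 3-methoxyphenyl in place of 4-methylphenyl on an oxygen on a saturated carbon. Among the measured compounds shown here, the one measured step that bears on this is an at least 3.5-fold higher number from compound 1 to compound 2 (0.54 log units; beyond the scatter) (methyl in place of methoxy on an aromatic carbon), which lies beyond the scatter. The entering group carries a methoxy again, so that step is read in reverse. A fall of similar size is therefore expected in this assay with a 2.9-fold lower number from compound 2 to compound 3 (0.46 log units; beyond the scatter) as the estimated step. Compound 3 is estimated at 12 h (range 5 h to 30 h).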

Compound 3, half-life: 24 h
For compound 3 the middle estimate is 2.0-fold (0.30 log units) below the measured one; low and high end bracket the measured number.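

In this assay, a methoxy group on the phenoxy ring does not by itself go with a short half-life: a 1.5-fold lower number from compound 2 to compound 3 (0.16 log units; within the scatter) stays within the scatter. With 3-methoxyphenyl in place of 4-methoxyphenyl, the data show an at least 2.4-fold higher number from compound 1 to compound 3 (0.38 log units; beyond the scatter), so the place of the methoxy matters in this pair. As far as these compounds go, compound 1 gives only a limit, < 10 h, and the true size of that step stays open. Also open, from the compounds shown here alone, is how a 3-methylphenyl group or an amine on the same ring would read in this assay.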